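The source may report more compounds than this note shows. Statements on the series, on what has been measured and on what is new or still open speak of the compounds shown alone.

Measured in a functional assay on MDA-MB-231 cells (Homo sapiens) for antiproliferative activity, read by MTT assay, with a stated time of 72 h (a higher number here means a weaker inhibitor, a lower number a stronger inhibitor), to date:
- compound 1 `O=C(CCc1cccc2c1B(O)OC2)Nc1ccccc1` gives 230 nM
- compound 2 `O=C(CCc1cccc2c1B(O)OC2)Nc1cccc(I)c1` gives 5300 nM
- compound 3 `O=C(CCc1cccc2c1B(O)OC2)Nc1cccc(-c2ccc(C(F)(F)F)cc2)c1` gives 510 nM
- compound 4 `N#Cc1ccc(-c2cccc(NC(=O)CCc3cccc4c3B(O)OC4)c2)cc1` is not yet measured

Compound 3 stands second highest of the three numbers, above compound 1 and below compound 2. Compound 4 carries cyano in place of trifluoromethyl on an aromatic carbon, para to a large group (cyano in place of trifluoromethyl on an aromatic carbon). Among the measured compounds shown here, no measured step exchanges these two groups. Placing 4-(trifluoromethyl)phenyl gave two steps, a 2.2-fold higher number from compound 1 to compound 3 (0.35 log units; beyond the scatter) (modest) and a 10-fold lower number from compound 2 to compound 3 (1.02 log units; beyond the scatter) (large), while iodo gave a large one, a 23-fold higher number from compound 1 to compound 2 (1.36 log units; beyond the scatter). Compound 4 keeps the added ring, so no change beyond the scatter is expected in this assay, and no direction is favoured. The expected step is a 1.1-fold lower number from compound 3 to compound 4 (0.05 log units; within the scatter) on this estimate. For compound 4 the estimated value is 450 nM with an expected range of 150 nM to 1400 nM for now.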

Compound 4, half-maximal inhibitory concentration: 380 nM
Estimate against measurement, compound 4: 1.2-fold (0.07 log units) above; measured number inside the range.
By their numbers in this assay, from the lowest: compounds 1, 4 and 3 (each within the scatter of the next, the first and the last beyond it); then compound 2.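

In this assay, exchanging the group on the added ring, para to a large group, can now be read directly: cyano in place of trifluoromethyl gives (a 1.3-fold lower number from compound 3 to compound 4 (0.13 log units; within the scatter)). With 4-cyanophenyl in place of hydrogen the step stays within the scatter (a 1.7-fold higher number from compound 1 to compound 4 (0.22 log units; within the scatter)), whereas the earlier step with 4-(trifluoromethyl)phenyl lies just beyond it. 4-Cyanophenyl in place of iodo gives a large step (a 14-fold lower number from compound 2 to compound 4 (1.14 log units; beyond the scatter)), and no measurement shown accounts for these results. On these data alone, whether an amine or a carboxylic acid at this place would fit the same reading remains open.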